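A few compounds are considered here, and "the series" means these few. Any claim that something is new, unique, unknown or untested is made for them only; others in the source may bear on it.

Measured compounds in a functional assay on HepG2 cells (Homo sapiens) for cytotoxicity, read by MTT assay, with a stated time of 48 h; on this read-out higher numbers stand for weaker inhibition and lower numbers for stronger inhibition: compound 1 `COc1ccc(-c2nnc(SCCn3c([N+](=O)[O-])cnc3C)o2)cc1` gives 5800 nM; compound 2 `Cc1ncc([N+](=O)[O-])n1CCSc1nnc(-c2ccc(N)cc2)o1` gives 6700 nM; compound 3 `Cc1ncc([N+](=O)[O-])n1CCSc1nnc(-c2ccccc2O)o1` gives 19600 nM.

Compound 1 stands at the lowest of the three numbers, though its step to compound 2 is a 1.2-fold higher number from compound 1 to compound 2 (0.06 log units; within the scatter), so the two cannot be ranked. Its step to compound 3 is a 3.4-fold higher number from compound 1 to compound 3 (0.53 log units; beyond the scatter), and compound 2 to compound 3 is a 2.9-fold higher number from compound 2 to compound 3 (0.47 log units; beyond the scatter). Compound 4 `Cc1ncc([N+](=O)[O-])n1CCSc1nnc(-c2ccnc(Cl)c2)o1` differs from compound 1 by 2-chloropyridin-4-yl in place of 4-methoxyphenyl on an aromatic carbon. Going by the values given here, no measured step exchanges the aromatic ring for one bearing a hetero atom or chlorine, so the closest guides are the small change of a 1.2-fold higher number from compound 1 to compound 2 (0.06 log units; within the scatter) and the modest rise in a 3.4-fold higher number from compound 1 to compound 3 (0.53 log units; beyond the scatter). Compound 4 is therefore expected at 7500 nM, between 2800 nM and 20000 nM, a step of a 1.3-fold higher number from compound 1 to compound 4 (0.11 log units; within the scatter) that may stay within the scatter.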

Compound 4, half-maximal inhibitory concentration: 11600 nM
Compound 4: middle estimate off by 1.5-fold (0.19 log units), on the low side; low and high end bracket the measured number.
By their numbers in this assay, from the lowest: compounds 1, 2, 4 and 3 (each within the scatter of the next, the first and the last beyond it).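

In this assay, the only ring at this position with a hetero atom and a chlorine stays within the scatter of all three other compounds: a 2.0-fold higher number from compound 1 to compound 4 (0.30 log units; within the scatter) and a 1.7-fold higher number from compound 2 to compound 4 (0.24 log units; within the scatter) and also a 1.7-fold lower number from compound 3 to compound 4 (0.23 log units; within the scatter). Thus 2-chloropyridin-4-yl cannot be ranked against 4-methoxyphenyl, 4-aminophenyl or 2-hydroxyphenyl, even though compound 1 and compound 3 stand apart. No evidence here explains this result.

As far as these compounds go, the ring nitrogen and the chlorine appear only together, so their separate contributions remain open. Also open, from the compounds shown here alone, is how an unsubstituted pyridine or a carboxylic acid on the ring would read.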